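Cytotoxicity check on a pyridinyl-to-pyrimidinyl swap

The source may hold more compounds than are shown below. What is called first, only, known or untested is meant among the compounds shown, and "the series" means these compounds.

Measured compounds:
compound 1 `Cc1ccc(C(=O)Nc2cc(-c3cnn(C)c3)cc(C(F)(F)F)c2)cc1Nc1cc(-c2cccnc2)ccn1` — in a toxicity assay on L02 cells (Homo sapiens) for cytotoxicity, read by MTT assay, with a stated time of 48 h (on this read-out lower numbers stand for stronger inhibition and higher numbers for weaker inhibition), compound 1 gives > 80000 nM, a limit of the assay.
compound 2 `Cc1cn(-c2cc(NC(=O)c3ccc(C)c(Nc4cc(-c5cccnc5)ccn4)c3)cc(C(F)(F)F)c2)cn1` — in this assay compound 2 gives > 80000 nM, likewise a limit.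

Compound 1 stands at the limit only; no number is known for it. Going by the values given here, the sole measured step, a step that the two limits leave unreadable from compound 1 to compound 2, cannot be read because the limit of > 80000 nM in this assay, at which 2 of the 2 values shown sit, holds both values. Compound 3 `Cc1ccc(C(=O)Nc2cc(-c3cnn(C)c3)cc(C(F)(F)F)c2)cc1Nc1cc(-c2cncnc2)ccn1` carries pyrimidin-5-yl in place of pyridin-3-yl on an aromatic carbon. Among the compounds with values here, no measured step bears on this change. The expected step of a number no higher from compound 1 to compound 3 (the limit leaves the size open) is taken as none beyond the scatter. Compound 3 is therefore expected to give 80000 nM in this assay, most likely again as a limit, within 40000 nM to 200000 nM.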

Compound 3, half-maximal inhibitory concentration: > 80000 nM
Compound 3: only a limit was reported; the forecaster's own chance of this, stated with the estimate: 85%; the middle value lies on the limit itself.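

The step from compound 1 to compound 3 cannot be read in this assay, and neither can any other step in the series: the limit of > 80000 nM in this assay, at which 3 of the 3 values shown sit.

The compounds shown leave open whether compound 1, compound 2 and compound 3 differ at all in this assay.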